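From a Bromophenyl Amide to a Phenylurea on One Core

The compounds below may be only part of what the source reports. "The series", "measured", "known", "first", "only" and "open" are said of these compounds alone.

Compound 1 `CN(C(=O)c1ccc(Br)cc1)c1ccc2[nH]c(-c3n[nH]c4ccccc34)cc2n1`: 1780 nM
Compound 2 `CN(C(=O)c1ccccc1)c1ccc2[nH]c(-c3n[nH]c4cc(C#N)ccc34)cc2n1`: 20900 nM
Compound 3 `COc1ccc(OC)c(S(=O)(=O)N(C)c2ccc3[nH]c(-c4n[nH]c5ccccc45)cc3n2)c1`: 4380 nM

Three compounds that share one core were tested in a functional assay on KB cells (Homo sapiens) for antiproliferative activity, read by MTT assay, with a stated time of 72 h; a higher number here means a weaker inhibitor, a lower number a stronger inhibitor. Compound 1 gives the lowest number of the three; compound 3 lies above it beyond the scatter, and compound 2 lies furthest above it. The three differ from one another in more than one place, so no single change can be read from them.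

Compound 4 `CN(C(=O)Nc1ccccc1)c1ccc2[nH]c(-c3n[nH]c4ccccc34)cc2n1` has not been measured. It differs from compound 1 by anilino in place of 4-bromophenyl on a carbonyl carbon. Among the measured compounds shown here, no measured pair shows how this change alone moves the number, so only a small step is expected, in either direction or none beyond the scatter: a 1.4-fold higher number from compound 1 to compound 4 (0.15 log units; within the scatter). Compound 4 is estimated at 2500 nM, within 800 nM to 8000 nM.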

Compound 4, half-maximal inhibitory concentration: 32 nM
The estimate for compound 4 lay 78-fold (1.89 log units) above the measured number, and the stated range ends above it.
By their numbers in this assay, from the lowest: compound 4; then compound 1; then compound 3; then compound 2.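

In this assay, among the compounds shown here, anilino in place of 4-bromophenyl on a carbonyl carbon gives a 56-fold lower number from compound 1 to compound 4 (1.75 log units; beyond the scatter) and is the only single change that can be read here. It shows that what sits on this carbonyl carbon can move the number strongly on the shared core. The anilino brings a hydrogen-bond donor that 4-bromophenyl lacks, but no measurement here links the drop to that donor or to the loss of bromine. The compounds shown leave open how a methylanilino or benzylamino group would behave at this place, and whether a 4-bromoanilino group would keep the low number.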